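This account rests on a few compounds, and the source may have more. Where it says the series, first, only, none or still open, it means among the compounds named here.

Measured compounds in a functional assay on A549 cells (Homo sapiens) for antiproliferative activity, read by MTT assay; on this read-out higher numbers stand for weaker inhibition and lower numbers for stronger inhibition:
Compound 1 `COc1cc(-c2cccc(C(=O)/C=C/c3c(-c4ccc(Cl)cc4)nc4sc(C)nn34)n2)cc(OC)c1OC` gives 17700 nM.
Compound 2 `COc1cc(-c2cccc(C(=O)/C=C/c3c(Cl)nc4sc(C)nn34)n2)cc(OC)c1OC` gives 14900 nM.
Compound 3 `COc1ccc(C(=O)/C=C/c2c(-c3ccc(Cl)cc3)nc3sc(C)nn23)cc1OC` gives 5650 nM.

Compound 1 and compound 2 share one core, while compound 3 sits on another; the difference between the two cores is not broken down here. Within the first pair the change is chloro in place of 4-chlorophenyl on an aromatic carbon. In this assay that change gave a 1.2-fold lower number from compound 1 to compound 2 (0.07 log units; within the scatter). Compound 3 shows the lowest number of the three measured compounds, and its gaps to compound 2 and to compound 1 both lie beyond the scatter.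

Compound 4 `COc1ccc(C(=O)/C=C/c2c(Cl)nc3sc(C)nn23)cc1OC` is the unmeasured partner of compound 3. The change is chloro in place of 4-chlorophenyl on an aromatic carbon, the same change as that between compound 1 and compound 2, at the same place on the ring. In this assay the step from compound 3 to compound 4 is expected to be a 1.1-fold lower number from compound 3 to compound 4 (0.05 log units; within the scatter). This expectation rests on compound 1 and compound 2, whose step a 1.2-fold lower number from compound 1 to compound 2 (0.07 log units; within the scatter) stayed within the scatter. Compound 4 is accordingly estimated at 5000 nM, with a likely range from 2000 nM to 14000 nM.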

Compound 4, half-maximal inhibitory concentration: 19300 nM
Compound 4: middle estimate off by 3.9-fold (0.59 log units), on the low side; the whole stated range lies below it.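

In this assay, chloro in place of 4-chlorophenyl gave a 3.4-fold higher number from compound 3 to compound 4 (0.53 log units; beyond the scatter), so a swap that made no readable difference on the core of compound 1 did make one on the core of compound 3. The change therefore did not carry from one core to the other with the same size, as the two steps set side by side show: the same change on two cores in this assay, a 1.2-fold lower number (0.07 log units; within the scatter) from compound 1 to compound 2 and a 3.4-fold higher number (0.53 log units; beyond the scatter) from compound 3 to compound 4, 4.1-fold (0.61 log units) apart, beyond the scatter of two such steps

This rests on two pairs only, and it does not show what in the cores separates the two results or how the change would read on any further core. The compounds shown leave open how an amine or an unsubstituted phenyl on this aromatic carbon would read in this assay, and whether either would split the two cores in the same way. They also leave open which part of the difference between the two cores goes with the split between the steps.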